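Swapping the piperazine substituent on the weaker amide

The compounds below may be only part of what the source reports. "The series", "measured", "known", "first", "only" and "open" are said of these compounds alone.

Compound 1 `Cc1nnc(SCC(=O)Nc2ccc(-c3nc(-c4ccccc4)c(-c4ccccc4)n3C)cc2)s1` and compound 2 `CN(C)/C=C/N1CCN(CC(=O)Nc2ccc(-c3nc(-c4ccccc4)c(-c4ccccc4)n3C)cc2)CC1` share a core and differ only in the group carried by the chain carbon bound to the carbonyl. In a functional assay on HT-29 cells (Homo sapiens) for cytotoxicity, read by MTT assay, with a stated time of 24 h, tested at 16 ug/mL (on this read-out lower numbers stand for a weaker effect and higher numbers for a stronger effect at the one concentration tested), compound 1 gives 83.3%, whereas compound 2 gives 28.2%, the lowest of the two numbers; the drop is a number 55.1 percentage points lower from compound 1 to compound 2 (beyond the scatter). Compound 3 `Cn1c(-c2ccc(NC(=O)CN3CCN(c4ccccc4)CC3)cc2)nc(-c2ccccc2)c1-c1ccccc1` keeps the piperazine of compound 2 and changes only its far nitrogen: phenyl in place of 2-(dimethylamino)ethenyl on an amine nitrogen in a ring. Among the measured compounds shown here, no measured step covers this change; the only step recorded replaced the whole side chain, so it tells little about trading one piperazine substituent for another. Compound 3 is therefore expected to stay near compound 2, with a step of a number 9.8 percentage points higher from compound 2 to compound 3 (within the scatter) in this assay, and its estimated value is 38% with a likely range from 12% to 68%.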

Compound 3, a percentage reported as activity, at one concentration (the size of the read-out at that concentration, not a potency): 55.4%
Compound 3: middle estimate off by 17.4 percentage points, on the low side, within the range that was stated.
By their numbers in this assay, from the lowest: compound 2; then compound 3; then compound 1.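

In this assay, the group on this ring nitrogen matters by itself: phenyl in place of 2-(dimethylamino)ethenyl gives a number 27.2 percentage points higher from compound 2 to compound 3 (beyond the scatter) while the rest of the molecule stays the same, something the earlier whole-side-chain swap could not separate. A piperazine side chain therefore does not by itself fix the read-out at the low number of compound 2, yet 4-phenylpiperazin-1-yl in place of (5-methyl-1,3,4-thiadiazol-2-yl)sulfanyl still gives a number 27.9 percentage points lower from compound 1 to compound 3 (beyond the scatter) in this comparison. Nothing available here explains either step.

From the compounds shown here alone, whether the rise needs an aromatic ring directly on this nitrogen stays open, as a methyl or benzyl group there would test. A phenyl ring carrying a chlorine or a methoxy group could show whether further change on the ring moves the number.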